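Adding a Second Chloro to the Core of Compound 1

A few compounds are considered here, and "the series" means these few. Any claim that something is new, unique, unknown or untested is made for them only; others in the source may bear on it.

Three compounds share one core and differ only in how two groups are arranged on the ring that hangs from it. Compound 1 `ClCc1ccc(Cn2cnc3c(Cl)ncnc32)cc1` gives 2950 nM in a functional assay on OVCAR-5 cells (Homo sapiens) for cytotoxicity, read by sulforhodamine B assay, with a stated time of 48 h; a higher number here means a weaker inhibitor of growth, a lower number a stronger inhibitor of growth. Compound 2 `ClCc1cccc(Cn2cnc3c(Cl)ncnc32)c1` gives 2080 nM in this assay, and compound 3 `ClCc1ccccc1Cn1cnc2ncnc(Cl)c21` gives 2810 nM. The number for compound 1 is the highest of the three, yet its gaps to compound 3 and to compound 2 both fall within the usual scatter, so the three cannot be told apart on these data. Going by the values given here, no measured pair shows the change now at hand. Compound 4 `ClCc1ccc(Cn2cnc3c(Cl)nc(Cl)nc32)cc1` differs from compound 1 by chloro in place of hydrogen on an aromatic carbon. Among the compounds with values here, with no measured step to lean on, the size of the change in this assay is uncertain; a step beyond the scatter in either direction cannot be ruled out, and the estimate leans only slightly toward a lower number. Compound 4 is therefore expected to give 2000 nM, within a range from 600 nM to 7000 nM. That estimate amounts to an expected step of a 1.5-fold lower number from compound 1 to compound 4 (0.17 log units; within the scatter).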

Compound 4, concentration for 50% growth inhibition: 18200 nM
Compound 4: the middle estimate sits 9.1-fold (0.96 log units) below what was measured; the whole stated range lies below it.
By their numbers in this assay, from the lowest: compounds 2, 3 and 1 (each within the scatter of the next); then compound 4.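

Chloro in place of hydrogen on an aromatic carbon, between two ring nitrogen atoms, is the first change in this series whose effect stands clear of the scatter: in this assay it produces a 6.2-fold higher number from compound 1 to compound 4 (0.79 log units; beyond the scatter) and so marks compound 4 as the weaker inhibitor of growth. The earlier compounds shown here, which differ only in how two groups are arranged on the hanging ring, could not be told apart, whereas this position on the shared core does move the number. This rests on a single pair, and no evidence at hand accounts for the step.

From the compounds shown here alone, whether an amine, a methoxy group or a fluoro at this position would move the number in the same direction remains open. So does whether the same chloro would bring a step of like size on the cores of compound 2 and compound 3.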